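The source may report more compounds than this note shows. Statements on the series, on what has been measured and on what is new or still open speak of the compounds shown alone.

Working notes on a series sharing one core. Compound 1 `O=C(CCCCCn1cc(Nc2ncc(Cl)c(Nc3ccc(Cl)cc3)n2)cn1)NO` was measured in a functional assay on Jurkat cells (Homo sapiens) for antiproliferative activity, read by MTT assay, with a stated time of 48 h (a higher number here means a weaker inhibitor, a lower number a stronger inhibitor), and gives 60 nM. Compound 2 `O=C(CCCCCn1cc(Nc2ncc(Cl)c(Nc3ccccc3Cl)n2)cn1)NO` gives 310 nM in this assay. Compound 3 `O=C(CCCCCCn1cc(Nc2ncc(Cl)c(Nc3ccccc3Cl)n2)cn1)NO` gives 250 nM in this assay. Compound 4 `O=C(CCCCCCn1cc(Nc2ncc(Cl)c(Nc3ccc(Cl)cc3)n2)cn1)NO` has not yet been measured in this assay.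

Compound 2 and compound 1 differ in one place: 4-chlorophenyl in place of 2-chlorophenyl on a nitrogen on an aromatic ring. That change gave a 5.2-fold lower number from compound 2 to compound 1 (0.71 log units; beyond the scatter). Compound 2 and compound 3 differ in the chain: (hydroxycarbamoyl)methyl in place of hydroxycarbamoyl on a saturated chain carbon, five bonds along the chain from an aromatic nitrogen. That change gave a 1.2-fold lower number from compound 2 to compound 3 (0.09 log units; within the scatter), so compound 2 and compound 3 cannot be separated by this readout. Compound 3 and compound 1 are separated more clearly, as their two numbers show.

Compound 4 differs from compound 3 by 4-chlorophenyl in place of 2-chlorophenyl on a nitrogen on an aromatic ring. This is the same change as from compound 2 to compound 1, and the place is the same word for word; it occurs twice among the compounds shown. Going by the values given here, the only precedent for the step is a 5.2-fold lower number from compound 2 to compound 1 (0.71 log units; beyond the scatter), and compound 3 gives 250 nM. The step is estimated as a 5.0-fold lower number from compound 3 to compound 4 (0.70 log units; beyond the scatter), carried over from that single precedent. Compound 4 is therefore expected to give about 50 nM in this assay. The range for compound 4 is estimated from 20 nM to 130 nM, wide since one precedent is all that supports it.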

Compound 4, half-maximal inhibitory concentration: 100 nM
Estimate against measurement, compound 4: 2.0-fold (0.30 log units) below; low and high end bracket the measured number.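

In this assay, 4-chlorophenyl in place of 2-chlorophenyl gives a 2.5-fold lower number from compound 3 to compound 4 (0.40 log units; beyond the scatter), the same direction as on the core of compound 1, and the two steps cannot be told apart in size: the same change on two cores in this assay, a 5.2-fold lower number (0.71 log units; beyond the scatter) from compound 2 to compound 1 and a 2.5-fold lower number (0.40 log units; beyond the scatter) from compound 3 to compound 4, 2.1-fold (0.32 log units) apart, within the scatter of two such steps. The chain change, (hydroxycarbamoyl)methyl in place of hydroxycarbamoyl, gives a 1.7-fold higher number from compound 1 to compound 4 (0.22 log units; within the scatter), and on both cores it stays within the scatter, so this readout shows no effect of that change on either core, and the two steps also agree with each other: the same change on two cores in this assay, a 1.2-fold lower number (0.09 log units; within the scatter) from compound 2 to compound 3 and a 1.7-fold higher number (0.22 log units; within the scatter) from compound 1 to compound 4, 2.1-fold (0.32 log units) apart, within the scatter of two such steps. Going by these compounds alone, this supports carrying both changes between these two cores in this assay, but with only two pairs for each change it does not fix the size of the aryl step, show that the step holds on any other core or in any other assay, or give a reason for it.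

The compounds shown leave open how a plain phenyl, a 4-fluorophenyl or a 4-methoxyphenyl would behave on the same nitrogen, and whether a shorter or a longer chain would stay as flat as this pair does. They also leave open what a carboxylic acid in place of the hydroxycarbamoyl end would give on either core.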